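The compounds below may be only part of what the source reports. "The series", "measured", "known", "first", "only" and "open" are said of these compounds alone.

Compound 2 `Oc1cc(C(F)(F)F)ccc1-c1nc(-c2ccccc2O)n(-c2cccc(Cl)c2)n1` and compound 1 `Oc1cc(C(F)(F)F)ccc1-c1nc(-c2ccccc2O)n(-c2ccc(Cl)cc2)n1` share the same core and differ only in the chlorophenyl group that sits on an aromatic nitrogen of that core. Within the data shown here, in a functional assay on PC-12 cells (Rattus norvegicus) for cytotoxicity, read by MTT assay, with stated times of 2 h and 24 h, tested at 5 uM (a lower number here means a weaker effect, a higher number a stronger effect of the compound at the concentration tested), compound 1 gives 87.3% and compound 2 gives 92.7%; the single measured step, a number 5.4 percentage points higher from compound 1 to compound 2 (within the scatter), lies within the scatter, so on these numbers the two compounds cannot be told apart. Compound 3 `Oc1cc(C(F)(F)F)ccc1-c1nc(-c2ccccc2O)n(-c2ccc(Cl)cc2Cl)n1` is the next compound to be measured. It differs from compound 2 in one place: 2,4-dichlorophenyl in place of 3-chlorophenyl on an aromatic nitrogen. Among the measured compounds shown here, the only step that bears on this change is a number 5.4 percentage points higher from compound 1 to compound 2 (within the scatter), which altered the chlorine pattern on the same ring without any change beyond the scatter. The step expected here is accordingly a number 2.7 percentage points lower from compound 2 to compound 3 (within the scatter), nothing beyond the scatter. Compound 3 is therefore estimated to give 90% in this assay, with a range from 78% to 98%.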

Compound 3, a percentage reported as activity, at one concentration (the size of the read-out at that concentration, not a potency): 86.7%
Compound 3: middle estimate off by 3.3 percentage points, on the high side, within the range that was stated.
By their numbers in this assay, from the lowest: compounds 3, 1 and 2 (each within the scatter of the next).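

Compound 3 shows that this site on the aromatic nitrogen tolerates more than a moved chlorine: adding a second chlorine also leaves the read-out of this assay within the scatter. Against the 3-chlorophenyl group, the 2,4-dichlorophenyl group gives a number 6 percentage points lower from compound 2 to compound 3 (within the scatter), and the cleaner comparison, a chloro in place of hydrogen on the 4-chlorophenyl ring, gives a number 0.6 percentage points lower from compound 1 to compound 3 (within the scatter). So across these three compounds, neither the place nor the number of chlorines separates them in this read-out, and nothing available explains why.

On these data alone, all three compounds still carry chlorine on this ring, so what a plain phenyl group would give remains open. So does the effect of a ring bearing an amine or a carboxylic acid, or of a methyl or a longer chain on this nitrogen.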